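A Thiophene Attachment Swap in Compound 3

This account rests on a few compounds, and the source may have more. Where it says the series, first, only, none or still open, it means among the compounds named here.

Compound 1 `Oc1ccc(-c2cc(-c3cccs3)cc(-c3ccccc3O)n2)cc1`: > 50000 nM
Compound 2 `Oc1ccc(-c2cc(-c3cccs3)cc(-c3cccc(O)c3)n2)cc1`: 780 nM

Among the measured compounds shown here, in a functional assay on T47D cells (Homo sapiens) for cytotoxicity, read by CCK-8 assay (a higher number here means a weaker inhibitor, a lower number a stronger inhibitor), compound 2 gives 780 nM, the only true number so far. Compound 1 shows > 50000 nM, which is a limit of the assay and not a number.

Compound 3 `Oc1ccc(-c2cc(-c3ccsc3)cc(-c3cccc(O)c3)n2)cc1` carries thiophen-3-yl in place of thiophen-2-yl on an aromatic carbon, opposite the ring nitrogen of the shared core (thiophen-3-yl in place of thiophen-2-yl on an aromatic carbon).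

For the measured compounds named here, the one measured step is an at least 64-fold lower number from compound 1 to compound 2 (1.80 log units; beyond the scatter). It is large, but it starts from the limit of > 50000 nM in this assay, at which 1 of the 2 values shown sits, and concerns the hydroxyphenyl group, leaving the thiophene untouched. Going by the values given here, no measured step tests the thiophene attachment, so this large step is not carried over. The step expected in this assay is a 1.2-fold higher number from compound 2 to compound 3 (0.06 log units; within the scatter), which means no expected change beyond the scatter. For compound 3 the estimated value is 900 nM, with an expected range from 300 nM to 2700 nM.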

Compound 3, half-maximal inhibitory concentration: 760 nM
Estimate against measurement, compound 3: 1.2-fold (0.07 log units) above; the range from low to high includes it.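

In this assay, the attachment of the thiophene on the aromatic carbon opposite the ring nitrogen is now tested directly, and the swap gives a 1.0-fold lower number from compound 2 to compound 3 (0.01 log units; within the scatter). For this pair, thiophen-3-yl therefore serves as well as thiophen-2-yl, whereas the earlier step spoke only to the hydroxyphenyl group and left this position untested. Nothing shown offers a cause for this sameness.

From the compounds shown here alone, only these two thiophene attachments appear at this position, so it remains open whether a phenyl ring, an amine or a carboxylic acid there would keep the value of compound 3 at 760 nM. Going by these compounds, compound 1 stands at > 50000 nM, which is a limit of the assay, and whether the thiophene swap would change anything on its 2-hydroxyphenyl background also remains open.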